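The compounds below may be only part of what the source reports. "The series", "measured", "known", "first", "only" and "open" are said of these compounds alone.

Values measured so far in an ADME assay on H9c2 cells (Rattus norvegicus) for cytotoxicity, read by resazurin assay, with a stated time of 72 h (on this read-out lower numbers stand for higher toxicity in this test and higher numbers for lower toxicity in this test), each of them a limit of the assay:

- Compound 1 `C/C(=N\Nc1nc(-c2ccc(C)cc2)cs1)c1ccc(Cl)c(Cl)c1`: > 50000 nM
- Compound 2 `C/C(=N\Nc1nc(-c2ccc(Cl)cc2)cs1)c1ccc(Cl)c(Cl)c1`: > 50000 nM
- Compound 3 `C/C(=N\Nc1nc(-c2ccc([N+](=O)[O-])cc2)cs1)c1ccc(Cl)c(Cl)c1`: > 50000 nM

Compound 3 has no number, only the limit > 50000 nM. It shares that position with the other two compounds, as the series shows (the limit of > 50000 nM in this assay, at which 3 of the 3 values shown sit).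

The next compound, compound 4 `C/C(=N\Nc1nc(-c2ccc(-c3ccccc3)cc2)cs1)c1ccc(Cl)c(Cl)c1`, carries phenyl in place of nitro on an aromatic carbon, para to a large group: phenyl in place of nitro on an aromatic carbon.

Among the measured compounds shown here, three measured steps bear on this change, all of them exchanges on an aromatic carbon, and none has a readable size: a step that the two limits leave unreadable from compound 1 to compound 2, a step that the two limits leave unreadable from compound 1 to compound 3 and a step that the two limits leave unreadable from compound 2 to compound 3. With the nitro exchange a step that the two limits leave unreadable from compound 2 to compound 3 as the nearest guide, no step beyond the scatter is expected in this assay, and no direction can be given. The expected step is a number no higher from compound 3 to compound 4 (the limit leaves the size open). Compound 4 is estimated at 50000 nM, with an expected range from 25000 nM to 100000 nM.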

Compound 4, half-maximal cytotoxic concentration: > 50000 nM
Compound 4 was reported as a limit; the forecaster's own chance of this, stated with the estimate: 80%; the middle value sits exactly at the limit.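

Among the compounds shown here, compound 4 is reported only as a limit, > 50000 nM, so no step to it from compound 1, compound 2 or compound 3 can be read. The compounds shown leave open whether any of these aromatic exchanges alters the read-out at all: the limit of > 50000 nM in this assay, at which 4 of the 4 values shown sit.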